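The compounds below may be only part of what the source reports. "The series", "measured", "known", "first", "only" and "open" are said of these compounds alone.

Measured compounds:
- compound 1 `COc1ccc(CCC(=O)N2CCN(c3ccc(C(F)(F)F)cc3[C@@H](N)CC(C)C)CC2)cc1`, 350 nM
- compound 2 `CC(C)C[C@H](N)c1cc(C(F)(F)F)ccc1N1CCN(C(=O)CCc2cccs2)CC1`, 4600 nM

In an assay on HEK293 cells for displacement of a labelled ligand from Melanocortin receptor 4 (Homo sapiens) (on this read-out lower numbers stand for stronger inhibition and higher numbers for weaker inhibition), compound 2 gives the highest of the two numbers; its nearest neighbour is compound 1, with a 13-fold higher number from compound 1 to compound 2 (1.12 log units; beyond the scatter) on the way from that compound to compound 2. Compound 3 `CC(C)C[C@H](N)c1cc(C(F)(F)F)ccc1N1CCN(C(=O)CCc2csc3ccccc23)CC1` is not yet measured in this assay. Its change from compound 2 is 1-benzothiophen-3-yl in place of thiophen-2-yl on a saturated chain carbon, two bonds along the chain from a carbonyl carbon. For the measured compounds named here, the single step that bears on this place is the one from compound 1 to compound 2, where swapping one aryl for another on the same chain carbon moved the number far beyond the scatter. Going by the values given here, a further aryl swap here can therefore move the number by a comparable amount; the direction is uncertain, since no measured compound carries a fused aryl at this place. The step from compound 2 to compound 3 is expected to be a 3.1-fold lower number from compound 2 to compound 3 (0.49 log units; beyond the scatter). Compound 3 is estimated at 1500 nM in this assay, with a range of 300 nM to 7000 nM.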

Compound 3, inhibition constant: 2300 nM
For compound 3 the middle estimate is 1.5-fold (0.19 log units) below the measured one, and the stated range covers the measured number.
By their numbers in this assay, from the lowest: compound 1; then compounds 3 and 2 (each within the scatter of the next).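

With 1-benzothiophen-3-yl in place of thiophen-2-yl on this chain carbon, the extra six-membered aromatic ring of carbon only gives a 2.0-fold lower number from compound 2 to compound 3 (0.30 log units; within the scatter) in this assay, so size alone, as counted in heavy atoms, does not separate these two groups here. The larger group also does not match 4-methoxyphenyl, with a 6.6-fold higher number from compound 1 to compound 3 (0.82 log units; beyond the scatter), so among the three compounds only compound 1 stands apart at this place. Nothing at hand bears on the reason for these differences.

The compounds shown leave open whether the methoxy group or the phenyl ring carrying it sets compound 1 apart, which an unsubstituted phenyl or a 4-chlorophenyl at the same place would help decide. Also open, on these data alone, is how a longer chain between the carbonyl and the aryl group would read.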